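This account rests on a few compounds, and the source may have more. Where it says the series, first, only, none or still open, it means among the compounds named here.

Compound 2 `CCCCc1cnc(CCc2ccc(-c3ccccc3C(=O)O)cc2)[nH]1` sits at the lower end of the two numbers gathered in an in vitro functional assay on cells for agonist activity at Bombesin receptor subtype-3 (Homo sapiens), read by luminescence and calcium flux (on this read-out lower numbers stand for an effect already at smaller amounts and higher numbers for an effect only at larger amounts of compound), where compound 2 gives 2710 nM. Among the measured compounds shown here, the only neighbour is compound 1 `COc1cccc(Cc2cnc(CCc3ccc(-c4ccccc4C(=O)O)cc3)[nH]2)c1`, which in this assay gives 4120 nM; the step of a 1.5-fold lower number from compound 1 to compound 2 (0.18 log units; within the scatter) lies within the scatter, so the two cannot be ranked.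

Compound 3 `CC(C)CCc1cnc(CCc2ccc(-c3ccccc3C(=O)O)cc2)[nH]1` carries the change (methyl in place of hydrogen on a saturated chain carbon bound to two saturated chain carbons), which turns butyl into isopentyl. For the measured compounds named here, only one measured step exists, and it swaps the whole group on the chain rather than branching it, so it bears on the new step only loosely; its size, a 1.5-fold lower number from compound 1 to compound 2 (0.18 log units; within the scatter), was itself within the scatter. Going by the values given here, no measured step therefore points to a shift beyond the scatter in this assay.

For compound 3 the expected step is a 1.2-fold lower number from compound 2 to compound 3 (0.07 log units; within the scatter), and compound 3 is estimated at 2300 nM, within 900 nM to 6000 nM.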

Compound 3, half-maximal effective concentration: 119 nM
Estimate against measurement, compound 3: 19-fold (1.29 log units) above, outside the stated range (below it).
By their numbers in this assay, from the lowest: compound 3; then compounds 2 and 1 (each within the scatter of the next).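

Adding one methyl on a saturated chain carbon bound to two saturated chain carbons, which turns butyl into isopentyl, gives a 23-fold lower number from compound 2 to compound 3 (1.36 log units; beyond the scatter) in this assay, so this part of the chain responds strongly to a change of a single carbon, something the earlier swap of whole groups, which stayed within the scatter, did not reveal. The same branched chain also separates clearly from the 3-methoxyphenyl end group, with a 35-fold lower number from compound 1 to compound 3 (1.54 log units; beyond the scatter). Nothing in the data shown accounts for the size of these steps.

The compounds shown leave open whether this carbon would accept an ethyl in place of the new methyl, a hydroxyl or an amine. They also leave open how a longer branched chain would read out.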